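Ester to acid with an amino group on the benzyl ring

The source may report more compounds than this note shows. Statements on the series, on what has been measured and on what is new or still open speak of the compounds shown alone.

Measured compounds:
compound 1, `COc1cccc([C@@H](CO)O[C@H]2CCCN(Cc3ccc(C(=O)O)cc3C)[C@H]2c2ccccc2)c1`, 81000 nM
compound 2, `COC(=O)c1ccc(CN2CCC[C@H](O[C@H](CO)c3cc(Cl)cc(Cl)c3)[C@@H]2c2ccccc2)c(C)c1`, 900 nM
compound 3, `Cc1cc(C(=O)O)ccc1CN1CCC[C@H](O[C@@H](CC(C)(C)O)c2cc(Cl)cc(Cl)c2)[C@@H]1c1ccccc1`, 330 nM

These three compounds were tested in an assay on isolated protein for activation of cGMP-dependent protein kinase 1 (Homo sapiens), read by ADP-Glo, with stated times of 30 min and 2 h, in the presence of a further agent that is not named here; a higher number here means that more compound is needed for the effect, a lower number that less compound is needed. Compound 2 gives 900 nM, the second highest of the three numbers: compound 3 lies lower, beyond the scatter, and compound 1 lies higher, far beyond the scatter. No two of these compounds differ in only one place, so no single step between them can be isolated.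

Compound 4, `Nc1cc(C(=O)O)ccc1CN1CCC[C@H](O[C@H](CO)c2cc(Cl)cc(Cl)c2)[C@@H]1c1ccccc1`, has not yet been measured. It differs from compound 2 as follows: a group of 10 heavy atoms (7 carbon, 1 nitrogen, 2 oxygen; one six-membered aromatic ring of carbon only) in place of a group of 11 heavy atoms (9 carbon, 2 oxygen; one six-membered aromatic ring of carbon only), on a saturated chain carbon bound to an amine nitrogen in a ring. Compound 3 carries the same carboxylic acid and gives 330 nM in this assay, lower than compound 2, which carries the methyl ester. On this limited basis a somewhat lower number is expected for compound 4, estimated as 450 nM, with a range from 150 nM to 1500 nM. That expectation corresponds to a step from compound 2 to compound 4 of a 2.0-fold lower number from compound 2 to compound 4 (0.30 log units; within the scatter), modest in size and not far beyond the scatter.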

Compound 4, half-maximal effective concentration: 290 nM
Beside the measured number, compound 4's estimate is 1.6-fold (0.19 log units) above it; measured number inside the range.
By their numbers in this assay, from the lowest: compounds 4 and 3 (each within the scatter of the next); then compound 2; then compound 1.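

Swapping the group on a saturated chain carbon bound to an amine nitrogen in a ring, from the methyl ester-bearing group to 2-amino-4-carboxyphenyl, gives in this assay a 3.1-fold lower number from compound 2 to compound 4 (0.49 log units; beyond the scatter). Going by these compounds alone, this is the first direct comparison in the set, and it shows that a change at this place alone can move the number beyond the usual scatter, though only modestly. The swap alters two features at once, the ester becoming a carboxylic acid and the methyl becoming an amino group, and no information here explains the step.

The compounds shown leave open whether the acid, the amino group or both together account for the lower number. They also leave open how a primary amide in place of the acid, or a chlorine in place of the amino group, would behave.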